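The compounds below may be only part of what the source reports. "The series", "measured", "known", "first", "only" and "open" are said of these compounds alone.

Measured in a functional assay on MDA-MB-231 cells (Homo sapiens) for antiproliferative activity, read by MTT assay, with a stated time of 72 h; a higher number here means a weaker inhibitor, a lower number a stronger inhibitor:
Compound 1 `CC1=CC[C@H]2[C@@H]1CC=C(C)[C@@H](CC[C@H]1[C@]3(C)CC[C@H](O)C(C)(C)O[C@H]3CC[C@@]1(C)O)C2(C)C`: > 50000 nM, a limit of the assay
Compound 2 `CC(=O)O[C@H]1CC[C@]2(C)[C@H](CC[C@@](C)(O)[C@H]2CC[C@@H]2C(C)=CC[C@@H]3C(C)=CC[C@@H]3C2(C)C)OC1(C)C`: 39200 nM
Compound 3 `CC1=CC[C@H]2[C@@H]1CC=C(C)[C@@H](CC[C@H]1[C@]3(C)CC[C@H](OC(=O)c4ccncc4)C(C)(C)O[C@H]3CC[C@@]1(C)O)C2(C)C`: 19100 nM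

Of the two actual numbers, compound 3 has the lower, and the gap to the other is a 2.1-fold lower number from compound 2 to compound 3 (0.31 log units; beyond the scatter). Compound 1 gives only a limit, so its comparison with the others is bounded on one side.

Compound 4 `CC1=CC[C@H]2[C@@H]1CC=C(C)[C@@H](CC[C@H]1[C@]3(C)CC[C@H](OC(=O)c4ccc(C)cc4)C(C)(C)O[C@H]3CC[C@@]1(C)O)C2(C)C` carries 4-methylphenyl in place of pyridin-4-yl on a carbonyl carbon. Within the data shown here, two measured steps bear on this change. One is an at least 2.6-fold lower number from compound 1 to compound 3 (0.41 log units; beyond the scatter), and the other, at the same carbonyl carbon, is a 2.1-fold lower number from compound 2 to compound 3 (0.31 log units; beyond the scatter). Both are small, and the acetyl step, an at least 1.2-fold lower number from compound 1 to compound 2 (0.10 log units; that floor lies within the scatter), has a floor within the scatter. Compound 4 keeps a six-membered aromatic ring on the carbonyl carbon, as compound 3 does, so no large shift is expected in this assay. The expected change is a 1.3-fold lower number from compound 3 to compound 4 (0.10 log units; within the scatter), which stays within the scatter. For compound 4 the estimated value is 15000 nM, with an expected range from 6000 nM to 40000 nM.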

Compound 4, half-maximal inhibitory concentration: 32700 nM
For compound 4 the middle estimate is 2.2-fold (0.34 log units) below the measured one; the measured number falls inside the stated range.
By their numbers in this assay, from the lowest: compounds 3, 4 and 2 (each within the scatter of the next, the first and the last beyond it). At a limit, above all of these: compound 1.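

In this assay, 4-methylphenyl in place of pyridin-4-yl on the carbonyl carbon gives a 1.7-fold higher number from compound 3 to compound 4 (0.23 log units; within the scatter), so the carbon-only ring and the ring with one hetero atom cannot be told apart here. The 4-methylphenyl group also cannot be told apart from methyl at this carbonyl carbon, at a 1.2-fold lower number from compound 2 to compound 4 (0.08 log units; within the scatter), whereas pyridin-4-yl gave a 2.1-fold lower number from compound 2 to compound 3 (0.31 log units; beyond the scatter), so a six-membered aromatic ring on that carbon does not by itself give a step beyond the scatter. Against the free hydroxyl, (4-methylphenyl)carbonyl allows only a floor, an at least 1.5-fold lower number from compound 1 to compound 4 (0.18 log units; that floor lies within the scatter), and that floor rests on a limit: the limit of > 50000 nM in this assay, at which 1 of the 4 values shown sits.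

From the compounds shown here alone, what pyridin-3-yl, a saturated amine or a longer alkyl chain would do on this carbonyl carbon stays open. Going by these compounds, it is also open whether any such group would take the number well under that of compound 3, at 19100 nM.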